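Aryl swap on the amine nitrogen of compound 1

The source may hold more compounds than are shown below. What is called first, only, known or untested is meant among the compounds shown, and "the series" means these compounds.

Among the measured compounds shown here, compound 1 `Cc1ccc(S(=O)(=O)/N=C(/CCNC2=CC(=O)c3ccccc3C2=O)Nc2ccc(F)cc2)cc1` stands at the highest of the two numbers so far in a functional assay on DU-145 cells (Homo sapiens) for cytotoxicity, read by MTT assay, with a stated time of 48 h (on this read-out higher numbers stand for weaker inhibition and lower numbers for stronger inhibition), giving 12200 nM. Its nearest neighbour is compound 2 `Cc1ccc(S(=O)(=O)/N=C(/CCNC2=CC(=O)c3ccccc3C2=O)Nc2ccccc2[N+](=O)[O-])cc1`, which in this assay gives 7590 nM; the step of a 1.6-fold lower number from compound 1 to compound 2 (0.21 log units; within the scatter) stays within the scatter. Compound 3 `Cc1ccc(S(=O)(=O)/N=C(/CCNC2=CC(=O)c3ccccc3C2=O)Nc2cccc(C(F)(F)F)c2)cc1` has not yet been measured. It differs from compound 1 by 3-(trifluoromethyl)phenyl in place of 4-fluorophenyl on an amine nitrogen. For the measured compounds named here, the one measured step that bears on this change, a 1.6-fold lower number from compound 1 to compound 2 (0.21 log units; within the scatter), also exchanges the aryl on the same amine nitrogen and lies within the scatter, so the set offers no sign that one aryl separates from another here. On that basis compound 3 is expected to show no step beyond the scatter, a 1.2-fold lower number from compound 1 to compound 3 (0.09 log units; within the scatter). The estimate for compound 3 in this assay is 10000 nM, with a range from 4000 nM to 25000 nM.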

Compound 3, half-maximal inhibitory concentration: 84100 nM
Compound 3: middle estimate off by 8.4-fold (0.92 log units), on the low side; measured number outside the range, above it.
By their numbers in this assay, from the lowest: compounds 2 and 1 (each within the scatter of the next); then compound 3.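

In this assay the aryl on the amine nitrogen proves able to shift the number after all: 3-(trifluoromethyl)phenyl gives a 6.9-fold higher number from compound 1 to compound 3 (0.84 log units; beyond the scatter) and an 11-fold higher number from compound 2 to compound 3 (1.04 log units; beyond the scatter), whereas the exchange of 4-fluorophenyl for 2-nitrophenyl had stayed within the scatter. This position therefore does not treat all aryl groups alike, and among the three compounds, compound 3 is the weakest inhibitor. Nothing available accounts for this loss of inhibition.

The compounds shown do not separate the trifluoromethyl group itself from its place on the ring, and a 4-(trifluoromethyl)phenyl or a 3-fluorophenyl on the same nitrogen would bear on that question. From the compounds shown here alone, how an unsubstituted phenyl or a pyridyl would stand at this position also remains open.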